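Removing One Methoxy From a Trimethoxyphenyl Sulfonamide

A few compounds are considered here, and "the series" means these few. Any claim that something is new, unique, unknown or untested is made for them only; others in the source may bear on it.

Compound 1 `COc1cc(NS(=O)(=O)c2ccc(N3CCNC3=O)cc2)cc(OC)c1OC` stands at the low end of the two numbers measured: in a functional assay (Homo sapiens) for antiproliferative activity, read by sulforhodamine B assay, with a stated time of 48 h (a higher number here means a weaker inhibitor, a lower number a stronger inhibitor), compound 1 gives 58 nM, while compound 2 `O=C1NCCN1c1ccc(S(=O)(=O)Nc2ccc3[nH]ccc3c2)cc1` gives 770 nM in this assay, a gap well beyond the usual scatter. Compound 3 `COc1cc(NS(=O)(=O)c2ccc(N3CCNC3=O)cc2)cc(OC)c1` has not yet been measured. It differs from compound 1 in one place: hydrogen in place of methoxy on an aromatic carbon. The methoxy that leaves sits on an aromatic carbon of a six-membered aromatic ring of carbon only, ortho to two methoxy groups and para to a large group. No measured pair shows this exact change, so the step has no direct precedent among these compounds. The comparison with compound 2, at 770 nM, shows only that the aryl bearing the sulfonamide nitrogen matters. The step is expected to weaken inhibition, a 5.2-fold higher number from compound 1 to compound 3 (0.71 log units; beyond the scatter), beyond the scatter. Compound 3 is expected to give 300 nM in this assay, within a range from 80 nM to 1500 nM.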

Compound 3, half-maximal inhibitory concentration: 280 nM
The estimate for compound 3 lay 1.1-fold (0.03 log units) above the measured number; the measured number falls inside the stated range.
By their numbers in this assay, from the lowest: compound 1; then compound 3; then compound 2.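

In this assay, for the compounds shown here, the step with hydrogen in place of methoxy, at the carbon ortho to two methoxy groups and para to a large group, gives a 4.8-fold higher number from compound 1 to compound 3 (0.68 log units; beyond the scatter) and is the first single-place change on this ring to be read. The step lies beyond the scatter, so this methoxy counts toward the number of compound 1, yet compound 3 still gives 280 nM in this assay, so inhibition does not vanish when the group leaves. Nothing in the data shown explains the rise in the number.

The compounds shown leave open whether a hydroxyl, a fluorine atom or an ethoxy on this aromatic carbon would stay with compound 1 or fall with compound 3. They also leave open what taking away either remaining methoxy group would do.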